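The source may hold more compounds than are shown below. What is called first, only, known or untested is meant among the compounds shown, and "the series" means these compounds.

Working notes on the series. Three members are measured in a functional assay on PC-12 cells (Rattus norvegicus) for cytotoxicity, read by MTT assay, with stated times of 3 h and 2 h, tested at 10 uM; on this read-out higher numbers stand for a stronger effect at the one concentration tested and lower numbers for a weaker effect: compound 1 `O=C(CCCCC1CCSS1)NCc1cn(CCCOc2ccc3ccc(=O)oc3c2)nn1` gives 40%, compound 2 `CC(=O)c1cc2ccc(OCCCn3cc(CNC(=O)CCCCC4CCSS4)nn3)cc2oc1=O` gives 38%, and compound 3 `O=C(CCCCC1CCSS1)NCc1cn(CCCOc2ccc3cc(-c4ccccc4)c(=O)oc3c2)nn1` gives 29.1%. Compound 3 carries the lowest number of the three, though its gap to compound 2 lies within the scatter; only a number 10.9 percentage points lower from compound 1 to compound 3 (beyond the scatter) is beyond it. The other steps, a number 2 percentage points lower from compound 1 to compound 2 (within the scatter) and a number 8.9 percentage points lower from compound 2 to compound 3 (within the scatter), are small as well.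

Compound 4 `O=C(CCCCC1CCSS1)NCc1cn(CCCOc2ccc3cc(-c4ccc(Br)cc4)c(=O)oc3c2)nn1` differs from compound 3 by bromo in place of hydrogen on an aromatic carbon. Going by the values given here, no measured step adds a halogen; the steps that do exist all change a group on the aromatic core of the shared scaffold and all read small. Hence in this assay compound 4 is expected to stay near compound 3, with a step of a number 2.1 percentage points lower from compound 3 to compound 4 (within the scatter) that is not expected to exceed the scatter. Compound 4 is estimated at 27%, between 15% and 40%.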

Compound 4, a percentage reported as activity, at one concentration (the size of the read-out at that concentration, not a potency): 63.3%
Compound 4: middle estimate off by 36.3 percentage points, on the low side; the whole stated range lies below it.
By their numbers in this assay, from the lowest: compounds 3, 2 and 1 (each within the scatter of the next, the first and the last beyond it); then compound 4.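

Going by these compounds alone, the change from phenyl to 4-bromophenyl gives a number 34.2 percentage points higher from compound 3 to compound 4 (beyond the scatter) in this assay, the first large step, so a single bromine atom on this ring counts for far more than the earlier changes. The 4-bromophenyl group also stands clear of the smaller substituents, with a number 23.3 percentage points higher from compound 1 to compound 4 (beyond the scatter) and a number 25.3 percentage points higher from compound 2 to compound 4 (beyond the scatter) on the same core, whereas phenyl alone gave a lower number than hydrogen. Nothing available explains the rise.

As far as these compounds go, whether the effect is specific to bromo remains open. Chloro or methoxy in the same place on the phenyl ring would test this.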